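The source may report more compounds than this note shows. Statements on the series, on what has been measured and on what is new or still open speak of the compounds shown alone.

Of the compounds shown here, two have so far been measured in an assay on cells for inhibition of Ectonucleotide pyrophosphatase/phosphodiesterase family member 1 (Homo sapiens), with a stated time of 60 min, tested at 1 uM; on this read-out higher numbers stand for more inhibition at the one concentration tested (going by the name of the read-out) and lower numbers for less inhibition. Compound 1 `COc1cc2nc(/C=C/c3ccccn3)nc(N3CCC(CCNS(N)(=O)=O)CC3)c2cc1OC` gives 85% in this assay. Compound 2 `CCCOc1cc2c(Cl)ncnc2cc1OC` gives 29%, the lower of the two numbers; its nearest neighbour on the numbers is compound 1, whose number stands higher by a gap beyond the usual scatter. Among the compounds with values here, no pair of measured compounds differs in a single place, so no single structural step has yet been measured in this assay, and the gap between compound 1 and compound 2 cannot be assigned to any one change.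

Compound 3 `CCCCOc1cc2c(Cl)ncnc2cc1OC` has not been measured yet. It differs from compound 2 as follows: methyl in place of hydrogen on a saturated chain carbon, three bonds along the chain from an oxygen on an aromatic ring. Read one bond further out, this is propyl to butyl on the chain three bonds along from the oxygen on the aromatic ring. With no measured step of this kind in the series, the step from compound 2 to compound 3 is expected to be small, a number 4 percentage points higher from compound 2 to compound 3 (within the scatter), with the number expected to stay about level, neither higher nor lower beyond the scatter. Compound 3 is therefore expected to give about 33% in this assay, estimated to lie between 15% and 55%.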

Compound 3, a percentage reported as inhibition, at one concentration (the size of the read-out at that concentration, not a potency): < 1%
Compound 3: a limit, no number; the forecaster's own chance of this, stated with the estimate: 0%; middle value at least 32 percentage points away from the limit.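

In this assay, within the data shown here, the change from propyl to butyl, methyl in place of hydrogen on a saturated chain carbon three bonds along the chain from an oxygen on an aromatic ring, is the first single-place step, and it gives a number at least 28 percentage points lower from compound 2 to compound 3 (beyond the scatter). Compound 3 gives < 1%, which is a limit of this assay and not a number: the limit of < 1% in this assay, at which 1 of the 3 values shown sits.

The read-out at this position therefore responds to a single added methyl at the end of the chain, something the earlier pair, which differs in more than one place, could not show. As far as these compounds go, one step at one chain length gives no trend, so it stays open how a pentyl chain, a branched chain or a chain ending in an amine or a hydroxyl would read in this assay. From the compounds shown here alone, whether lengthening a chain at this place has a similar outcome on the core of compound 1 also stays open.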